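The compounds below may be only part of what the source reports. "The series", "measured", "known", "first", "only" and "open" are said of these compounds alone.

In a functional assay on C6 cells (Rattus norvegicus) for cytotoxicity, read by MTT assay, with a stated time of 24 h (on this read-out lower numbers stand for stronger inhibition and higher numbers for weaker inhibition), the measured compounds stand as follows:

Compound 1 `Cc1nnc(SCC(=O)N/N=c2/scc(-c3ccccc3)n2-c2ccccc2)s1` — > 200 ug/mL, a limit of the assay rather than a number.
Compound 2 `Cc1ccc(-c2cs/c(=N/NC(=O)CSc3nnnn3C)n2-c2ccccc2)cc1` — 36.3 ug/mL.
Compound 3 `Cn1nnnc1SCC(=O)N/N=c1/scc(-c2ccc(C#N)cc2)n1-c1ccccc1` — 23.3 ug/mL.

Of the two numbers that are numbers, compound 3 supplies the one at the low end, yet the step of a 1.6-fold lower number from compound 2 to compound 3 (0.19 log units; within the scatter) stays within the scatter, so compound 2 and compound 3 cannot be told apart on this read-out. Compound 1 sits at the limit of > 200 ug/mL in this assay, at which 1 of the 3 values shown sits, which is a limit and nothing more.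

Compound 4 `Cn1nnnc1SCC(=O)N/N=c1/scc(-c2ccccc2)n1-c1ccccc1` differs from compound 3 in one place: hydrogen in place of cyano on an aromatic carbon. Among the measured compounds shown here, no measured step follows exactly this change. For the measured compounds named here, the only measured step on the same ring, cyano in place of methyl, is a 1.6-fold lower number from compound 2 to compound 3 (0.19 log units; within the scatter) and lies within the scatter. Compound 1 carries an unsubstituted phenyl too, but its other ring also differs from that of compound 4, so its limit cannot be carried over. On this basis the step of a 1.5-fold higher number from compound 3 to compound 4 (0.18 log units; within the scatter) is expected to be small, with a lean toward a somewhat higher number for compound 4. Compound 4 is therefore estimated at 35 ug/mL, between 15 ug/mL and 90 ug/mL.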

Compound 4, half-maximal inhibitory concentration: 67.7 ug/mL
The estimate for compound 4 lay 1.9-fold (0.29 log units) below the measured number; the range from low to high includes it.
By their numbers in this assay, from the lowest: compounds 3, 2 and 4 (each within the scatter of the next, the first and the last beyond it). At a limit, above all of these: compound 1.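

Among the compounds shown here, with the 1-methyl-1H-tetrazol-5-yl group held fixed in this assay, the change from 4-cyanophenyl to phenyl (a 2.9-fold higher number from compound 3 to compound 4 (0.46 log units; beyond the scatter)) is the first step on this ring to pass the scatter, which shows that the read-out does respond to what this position carries. The step with hydrogen in place of methyl (a 1.9-fold higher number from compound 2 to compound 4 (0.27 log units; within the scatter)) stays within the scatter, so among these three groups only cyano and hydrogen can be told apart, and methyl cannot be separated from either. The group on the sulfur also matters when the phenyl is unsubstituted (an at least 2.9-fold lower number from compound 1 to compound 4 (0.47 log units; beyond the scatter)), although the compound 1 end of that step is a limit and not a number: the limit of > 200 ug/mL in this assay, at which 1 of the 4 values shown sits.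

Nothing shown explains why the cyano group gives the lower number, and this single pair cannot show whether the difference would persist on another core. The compounds shown also leave open whether an amine, a carboxylic acid or a methoxy group at this place would stand with compound 3 or with compound 4, and whether 4-cyanophenyl would give a measurable number with 5-methyl-1,3,4-thiadiazol-2-yl on the sulfur.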